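Series notes: compound 1 to compound 4

A few compounds are considered here, and "the series" means these few. Any claim that something is new, unique, unknown or untested is made for them only; others in the source may bear on it.

Measured so far in a functional assay on MCF7 cells (Homo sapiens) for antiproliferative activity, read by MTT assay, with a stated time of 48 h, tested at 25 uM; a lower number here means a stronger effect, a higher number a weaker effect of the compound at the concentration tested:
- compound 1 `COc1cccc(C(O)CCn2nc3c(Br)c(Br)c(Br)c(Br)c3n2)c1`: 96%
- compound 2 `C[C@@H](O)CCn1nc2c(Br)c(Br)c(Br)c(Br)c2n1`: 77%
- compound 3 `C[C@H](O)CCn1nc2c(Br)c(Br)c(Br)c(Br)c2n1`: 89%

Compound 1 gives the highest of the three numbers; compound 3 lies within the usual scatter of it, while compound 2 lies beyond it. Within the data shown here, the only step between measured compounds is a number 12 percentage points higher from compound 2 to compound 3 (beyond the scatter), which rests on the fact that compounds 2 and 3 differ only in the configuration as drawn and says nothing about the aryl group.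

Compound 4 `OC(CCn1nc2c(Br)c(Br)c(Br)c(Br)c2n1)c1ccc(Br)cc1` differs from compound 1 by 4-bromophenyl in place of 3-methoxyphenyl on a saturated chain carbon bound to an oxygen on a saturated carbon and a saturated chain carbon. Among the measured compounds shown here, no measured step bears on this change, so for compound 4 a step of a number 4 percentage points lower from compound 1 to compound 4 (within the scatter) is expected, that is, none beyond the scatter. Compound 4 is therefore estimated at 92%, in the range 78% to 104%.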

Compound 4, a percentage reported as activity, at one concentration (the size of the read-out at that concentration, not a potency): 105%
Estimate against measurement, compound 4: 13 percentage points below; measured number above the stated range.
By their numbers in this assay, from the lowest: compound 2; then compounds 3, 1 and 4 (each within the scatter of the next, the first and the last beyond it).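

At the saturated chain carbon bound to an oxygen on a saturated carbon, 4-bromophenyl in place of 3-methoxyphenyl gives a number 9 percentage points higher from compound 1 to compound 4 (within the scatter) in this assay. This exchange of aryl groups therefore shows no effect on the read-out beyond the usual scatter, a point the earlier stereochemical pair could not address. Nothing at hand bears on this aryl exchange.

Still open, going by these compounds, is whether a carboxylic acid or an amine in place of the aryl group would read differently at this carbon. The two drawn configurations at this carbon also remain uncompared for compounds carrying an aryl group.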